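The source may hold more compounds than are shown below. What is called first, only, known or untested is meant among the compounds shown, and "the series" means these compounds.

Measured compounds:
compound 1, `NS(=O)(=O)NCCCC[C@H](NC(=O)OCc1cccc(Cl)c1)C(=O)Nc1nc(-c2ccccc2)cs1`, 280 nM
compound 2, `NS(=O)(=O)NCCCC[C@H](NC(=O)OCc1cccnc1)C(=O)Nc1nc(-c2ccccc2)cs1`, 600 nM
compound 3, `CCOC(=O)N[C@@H](CCCCNS(N)(=O)=O)C(=O)Nc1nc(-c2ccccc2)cs1`, 200 nM

All three share a core, and in an assay for inhibition of protein deacetylase HDAC6 (Homo sapiens) (on this read-out higher numbers stand for weaker inhibition and lower numbers for stronger inhibition), they differ only at the group on a saturated chain carbon bound to an oxygen next to a carbonyl group. Compound 3 gives the lowest number of the three, but its separation from compound 1 is a 1.4-fold lower number from compound 1 to compound 3 (0.15 log units; within the scatter), which lies within the scatter, while its separation from compound 2 is a 3.0-fold lower number from compound 2 to compound 3 (0.48 log units; beyond the scatter).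

Compound 4, `NS(=O)(=O)NCCCC[C@H](NC(=O)Nc1ccccc1)C(=O)Nc1nc(-c2ccccc2)cs1`, is not yet measured. It differs from compound 3 by anilino in place of ethoxy on a carbonyl carbon; the same difference, cut one bond further out, reads ethoxycarbonyl to phenylcarbamoyl. Going by the values given here, no measured step makes exactly this change. The steps that come closest all sit one bond further out, on the saturated chain carbon: a 2.1-fold higher number from compound 1 to compound 2 (0.33 log units; beyond the scatter), a 1.4-fold lower number from compound 1 to compound 3 (0.15 log units; within the scatter) and a 3.0-fold lower number from compound 2 to compound 3 (0.48 log units; beyond the scatter). All of them are modest or within the scatter, which suggests that this part of the molecule tolerates variation without large shifts. Compound 4 is therefore expected to give a number close to that of compound 3, with a step of a 1.3-fold higher number from compound 3 to compound 4 (0.10 log units; within the scatter). The estimate for compound 4 is 250 nM, with a range from 100 nM to 650 nM.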

Compound 4, half-maximal inhibitory concentration: 560 nM
Compound 4: middle estimate off by 2.2-fold (0.35 log units), on the low side; low and high end bracket the measured number.
By their numbers in this assay, from the lowest: compounds 3, 1, 4 and 2 (each within the scatter of the next, the first and the last beyond it).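

In this assay, putting anilino in place of ethoxy on a carbonyl carbon brings in a six-membered aromatic ring of carbon only and a hydrogen-bond donor, and it gives a step beyond the scatter, a 2.8-fold higher number from compound 3 to compound 4 (0.45 log units; beyond the scatter), of similar modest size to the earlier 3.0-fold lower number from compound 2 to compound 3 (0.48 log units; beyond the scatter). Against the two compounds with larger groups at this place, no separation can be read: a 1.1-fold lower number from compound 2 to compound 4 (0.03 log units; within the scatter) and a 2.0-fold higher number from compound 1 to compound 4 (0.30 log units; within the scatter) both lie within the scatter, so only compound 3 stands clear of compound 4. The earlier compounds shown here varied only the group on the saturated chain carbon and kept the oxygen, whereas compound 4 changes the atom on the carbonyl carbon itself, and the numbers still stay within the modest range seen so far.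

No available evidence bears on what lies behind this step. Ethoxy and anilino differ in both the linking atom and the ring at once, so the contribution of each stays open, and phenoxy or ethylamino on the same carbonyl carbon would be the groups that pull the two apart.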